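This account rests on a few compounds, and the source may have more. Where it says the series, first, only, none or still open, it means among the compounds named here.

Compound 1 `CC1=C(C(=O)OC(C)(C)C)C(c2ccsc2)NC(=O)N1` gives 15% in an assay on membranes from CHO cells for displacement of a labelled ligand from adenosine receptor A1 (Homo sapiens), read by scintillation counting, with a stated time of 60 min, tested at 1 uM; on this read-out lower numbers stand for less inhibition and higher numbers for more inhibition at the one concentration tested (going by the name of the read-out). Compound 2 `CC1=C(C(=O)NC(C)C)C(c2ccco2)NC(=O)N1` gives 3%. Compound 3 `CC1=C(C(=O)NC(C)C)C(c2ccoc2)NC(=O)N1` gives 1%.

Compound 3 stands lowest of these three numbers. Its nearest neighbour is compound 2, the step being a number 2 percentage points lower from compound 2 to compound 3 (within the scatter). For the measured compounds named here, compound 1, with its own value of 15%, lies further away, beyond the scatter, but it differs from compound 3 in more than one place, so no single step is known for that pair.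

Compound 4 `CC1=C(C(=O)NC(C)C)C(c2ccsc2)NC(=O)N1` differs from compound 3 by thiophen-3-yl in place of furan-3-yl on a saturated ring carbon. Going by the values given here, no measured step exchanges oxygen for sulfur in this ring; the only single step known, a number 2 percentage points lower from compound 2 to compound 3 (within the scatter), changed the attachment point of the ring and stayed within the scatter. The change to compound 4 is therefore expected to give no step beyond the scatter, with a number 7 percentage points higher from compound 3 to compound 4 (within the scatter) as the estimated step. For compound 4 the expected value in this assay is 8%, in a range from 0% to 25%.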

Compound 4, a percentage reported as inhibition, at one concentration (the size of the read-out at that concentration, not a potency): 8%
Estimate against measurement, compound 4: no gap at the digits printed; low and high end bracket the measured number.
By their numbers in this assay, from the lowest: compounds 3, 2, 4 and 1 (each within the scatter of the next, the first and the last beyond it).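

In this assay, thiophen-3-yl in place of furan-3-yl on the saturated ring carbon gives a number 7 percentage points higher from compound 3 to compound 4 (within the scatter), and thiophen-3-yl in place of furan-2-yl gives a number 5 percentage points higher from compound 2 to compound 4 (within the scatter), so these three five-membered aromatic rings read alike here. With thiophen-3-yl held fixed, isopropylamino in place of tert-butoxy on the carbonyl carbon gives a number 7 percentage points lower from compound 1 to compound 4 (within the scatter), which is also a small change. Nothing available explains these numbers. On these data alone, whether a phenyl or cyclohexyl ring on that saturated carbon would shift the number beyond the scatter stays open. The same holds for a longer chain on the amide nitrogen.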